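The compounds below may be only part of what the source reports. "The series", "measured", "known", "first", "only" and "open" are said of these compounds alone.

Measured so far:
compound 1 `O=S(=O)(NCCCNc1nccc(-c2c(-c3cccc(F)c3)nc3sccn23)n1)c1ccc(Br)cc1`, 7040 nM
compound 2 `O=S(=O)(NCCNc1nccc(-c2c(-c3cccc(F)c3)nc3sccn23)n1)c1ccc(F)cc1`, 9450 nM
compound 3 `O=C(NCCCNc1nccc(-c2c(-c3cccc(F)c3)nc3sccn23)n1)c1ccc(Cl)cc1`, 13700 nM

All three share one core and differ only in the side chain that hangs from the nitrogen on the aromatic ring. In a functional assay on A-375 cells (Homo sapiens) for cytotoxicity, read by MTT assay (on this read-out lower numbers stand for stronger inhibition and higher numbers for weaker inhibition), compound 1 gives 7040 nM, the lowest of the three numbers, but every step from it stays within the scatter: a 1.3-fold higher number from compound 1 to compound 2 (0.13 log units; within the scatter) and a 1.9-fold higher number from compound 1 to compound 3 (0.29 log units; within the scatter). The three compounds therefore read as one group of roughly equal potency.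

Compound 4 `O=S(=O)(NCCNc1nccc(-c2c(-c3cccc(F)c3)nc3sccn23)n1)c1ccccc1` has not yet been measured. Compared with compound 1 the change is (phenylsulfonyl)amino in place of (((4-bromophenyl)sulfonyl)amino)methyl on a saturated chain carbon, two bonds along the chain from a nitrogen on an aromatic ring. This resembles the step from compound 1 to compound 2, which shortened the chain and swapped the halogen on the ring; that step was a 1.3-fold higher number from compound 1 to compound 2 (0.13 log units; within the scatter). Compound 4 keeps the shorter chain of compound 2 but carries no halogen at all. With every step among the measured compounds inside the scatter, no move beyond the scatter is expected here either. For compound 4 the estimate is 9500 nM (range 4000 nM to 22000 nM), an expected step of a 1.3-fold higher number from compound 1 to compound 4 (0.13 log units; within the scatter).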

Compound 4, half-maximal inhibitory concentration: 11000 nM
For compound 4 the middle estimate is 1.2-fold (0.06 log units) below the measured one, and the stated range covers the measured number.
By their numbers in this assay, from the lowest: compounds 1, 2, 4 and 3 (each within the scatter of the next).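

In this assay, among the compounds shown here, hydrogen in place of fluoro on an aromatic carbon gives a 1.2-fold higher number from compound 2 to compound 4 (0.07 log units; within the scatter) and so isolates the ring substituent on the shorter chain, a comparison the earlier compounds did not offer: losing the halogen there leaves the number within the scatter. The larger change from the sulfonamide of compound 1 also stays within the scatter at a 1.6-fold higher number from compound 1 to compound 4 (0.19 log units; within the scatter) and so does the change from the amide of compound 3 at a 1.2-fold lower number from compound 3 to compound 4 (0.10 log units; within the scatter) and this position has so far tolerated all these variations without a clear shift. Nothing available explains this flat response.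

The compounds shown leave open whether any change to this side chain can move the number beyond the scatter. An amine or a carboxylic acid on the phenyl ring, or a longer chain than that of compound 1, would test this.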